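Working notes: methylamino to morpholin-4-yl on a carbonyl carbon

The source may report more compounds than this note shows. Statements on the series, on what has been measured and on what is new or still open speak of the compounds shown alone.

In an in vitro ADME assay on microsomes from liver (Rattus norvegicus) for metabolic stability (on this read-out higher numbers stand for fast clearance and lower numbers for slow clearance), compound 1 (`CCC(CC)[C@@H]1C(=O)N[C@H](C2Cc3ccccc3C2)C(=O)N1[C@@H](C(=O)N1CCOCC1)c1ccc(C)nc1`) gives 1 mL.min-1.g-1 and compound 2 (`CCC(CC)[C@@H]1C(=O)N[C@H](C2Cc3ccccc3C2)C(=O)N1[C@@H](C(=O)NC)c1ccc(C)nc1C`) gives 2 mL.min-1.g-1. These two values lie within the scatter of each other. Compound 3 (`CCC(CC)[C@@H]1C(=O)N[C@H](C2Cc3ccccc3C2)C(=O)N1[C@@H](C(=O)N1CCOCC1)c1ccc(C)nc1C`) differs from compound 2 in one place: morpholin-4-yl in place of methylamino on a carbonyl carbon. Among the measured compounds shown here, no measured pair shows this change. A step beyond the scatter in this assay is therefore not expected, in either direction. The estimated step of a 1.3-fold lower number from compound 2 to compound 3 (0.12 log units; within the scatter) stays within the scatter. Compound 3 is expected at 1.5 mL.min-1.g-1, with an estimated range of 0.7 mL.min-1.g-1 to 3.5 mL.min-1.g-1.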

Compound 3, intrinsic clearance in microsomes: 1 mL.min-1.g-1
Beside the measured number, compound 3's estimate is 1.5-fold (0.18 log units) above it; the measured number falls inside the stated range.
By their numbers in this assay, from the lowest: compounds 1, 3 and 2 (each within the scatter of the next).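

In this assay, morpholin-4-yl in place of methylamino on a carbonyl carbon now has a measured pair, reading as a 2.0-fold lower number from compound 2 to compound 3 (0.30 log units; within the scatter) with nothing beyond the scatter. Methyl in place of hydrogen on an aromatic carbon reads as no change at the digits printed from compound 1 to compound 3 (within the scatter) and likewise stays inside it, so neither change separates these compounds on this read-out. No supporting data bear on these readings. Still open, from the compounds shown here alone, is whether piperidin-1-yl or dimethylamino on that carbonyl carbon would give a step beyond the scatter.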